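A few compounds are considered here, and "the series" means these few. Any claim that something is new, unique, unknown or untested is made for them only; others in the source may bear on it.

Working notes on the series. In a functional assay on BGC-823 cells (Homo sapiens) for antiproliferative activity, read by MTT assay, tested at 5 uM (a higher number here means a stronger effect of the compound at the concentration tested, a lower number a weaker effect), compound 1 `COc1cc(C(=O)N/N=C/c2ccccc2C(F)(F)F)cc(OC)c1OC` gives 35.6%, compound 2 `COc1cc(C(=O)N/N=C/c2cccc(F)c2)cc(OC)c1OC` gives 44.8%, and compound 3 `COc1cc(C(=O)N/N=C/c2ccc(F)cc2)cc(OC)c1OC` gives 61.1%. Compound 3 stands highest of the three numbers in this assay; its nearest neighbour is compound 2, with compound 1 furthest off, and both gaps lie beyond the scatter.

The next step goes from compound 3 to compound 4 `COc1cc(C(=O)N/N=C/c2ccccc2F)cc(OC)c1OC`: 2-fluorophenyl in place of 4-fluorophenyl on a carbon with a double bond to nitrogen. Among the measured compounds shown here, the one measured step that bears on moving the fluorine around the ring is a number 16.3 percentage points higher from compound 2 to compound 3 (beyond the scatter), which shows the fluorophenyl position matters to a modest degree in this assay. For the measured compounds named here, for the 2-position there is no measured step with fluorine; compound 1, which carries trifluoromethyl at the 2-position, has the lowest number of the set, and only its value can be read, not a step. On this basis a drop beyond the scatter is expected, of about a number 19.1 percentage points lower from compound 3 to compound 4 (beyond the scatter). Compound 4 is therefore estimated at 42% in this assay, with a range from 25% to 58%.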

Compound 4, a percentage reported as inhibition, at one concentration (the size of the read-out at that concentration, not a potency): 76.5%
Estimate against measurement, compound 4: 34.5 percentage points below; measured number above the stated range.
By their numbers in this assay, from the lowest: compounds 1 and 2 (each within the scatter of the next); then compound 3; then compound 4.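

In this assay the move to 2-fluorophenyl gives a number 15.4 percentage points higher from compound 3 to compound 4 (beyond the scatter) and a number 31.7 percentage points higher from compound 2 to compound 4 (beyond the scatter); compound 4 therefore stands highest of the series, and the three fluorophenyl compounds separate in the order 3-fluorophenyl, 4-fluorophenyl, 2-fluorophenyl, each gap beyond the scatter. The low number of compound 1 cannot be taken as a mark against every group at that place on the ring, since fluoro in place of trifluoromethyl on an aromatic carbon gives a number 40.9 percentage points higher from compound 1 to compound 4 (beyond the scatter). Nothing at hand accounts for this order among the fluorophenyl compounds.

Going by these compounds, it remains open whether 2-chlorophenyl, 2-methoxyphenyl or 2-aminophenyl would hold the number of compound 4 in this assay. Among the compounds shown here, these single-concentration read-outs also show only that compound 4 has a stronger effect than the other compounds at the concentration tested, and say nothing of its effect at any other concentration.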